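Shortening the chain on the anilino nitrogen

The compounds below may be only part of what the source reports. "The series", "measured", "known", "first", "only" and "open" are said of these compounds alone.

Of the compounds shown here, three sharing one core have been measured in an ADME assay on isolated protein for inhibition of Dihydrofolate reductase (Homo sapiens), using NADPH; on this read-out higher numbers stand for weaker inhibition and lower numbers for stronger inhibition. Compound 1 `Nc1nc(N)c2nc(Nc3ccccc3)ccc2n1` carries a hydrogen on the nitrogen that joins the phenyl ring to the core, and compound 1 gives 1530 nM. Compound 2 `CN(c1ccccc1)c1ccc2nc(N)nc(N)c2n1` has a methyl there instead, and compound 2 gives 942 nM. Compound 3 `CCCCN(c1ccccc1)c1ccc2nc(N)nc(N)c2n1` has a butyl on that nitrogen, and compound 3 gives 903 nM. The number for compound 3 sits at the low end of the three, but the steps of a 1.7-fold lower number from compound 1 to compound 3 (0.23 log units; within the scatter) and a 1.0-fold lower number from compound 2 to compound 3 (0.02 log units; within the scatter) show that its distance from the others is no larger than the scatter of repeat measurements; the step of a 1.6-fold lower number from compound 1 to compound 2 (0.21 log units; within the scatter) is of the same kind.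

Compound 4 `CCN(c1ccccc1)c1ccc2nc(N)nc(N)c2n1` differs from compound 3 by hydrogen in place of ethyl on a saturated chain carbon, two bonds along the chain from a nitrogen on an aromatic ring, so an ethyl now sits on the nitrogen. The step from compound 2 to compound 3, which adds a propyl to the methyl carbon, and the steps from compound 1 to compounds 2 and 3 all stayed within the scatter, so no step beyond the scatter in this assay is expected here either, in any direction; the expected step is a 1.0-fold higher number from compound 3 to compound 4 (0.01 log units; within the scatter). Compound 4 is therefore estimated at 920 nM, with a likely range from 550 nM to 1600 nM.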

Compound 4, half-maximal inhibitory concentration: 1570 nM
Compound 4: the middle estimate sits 1.7-fold (0.23 log units) below what was measured, and the stated range covers the measured number.
By their numbers in this assay, from the lowest: compounds 3, 2, 1 and 4 (each within the scatter of the next).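

Putting an ethyl on the nitrogen fills the gap between the methyl and the butyl, and in this assay this fourth group also gives no step beyond the scatter. Removing the outer ethyl of the butyl chain gives the first step (a 1.7-fold higher number from compound 3 to compound 4 (0.24 log units; within the scatter)), adding a methyl to the methyl on the nitrogen gives the second (a 1.7-fold higher number from compound 2 to compound 4 (0.22 log units; within the scatter)), and replacing the hydrogen on the nitrogen with ethyl gives the third (a 1.0-fold higher number from compound 1 to compound 4 (0.01 log units; within the scatter)). Hydrogen, methyl, ethyl and butyl on this nitrogen therefore cannot be told apart on this read-out, and the four compounds show no trend with chain length, while nothing available offers an explanation for these numbers.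

The four compounds cover only hydrogen and plain saturated chains up to butyl, so they leave open whether a longer chain, such as octyl, would also stay within the scatter. They also leave open whether a chain ending in an amine or a carboxylic acid, or a benzyl group, on this same nitrogen would produce a step that can be read beyond the scatter.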